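The compounds below may be only part of what the source reports. "The series", "measured", "known", "first", "only" and "open" are said of these compounds alone.

Notes on the series. Compound 1, `CC(Oc1ccccc1-c1ccc([N+](=O)[O-])cc1)C1=NCCN1`, gives in an assay on CHO cells for displacement of a labelled ligand from Alpha-2B adrenergic receptor (Homo sapiens) (a lower number here means a stronger inhibitor, a higher number a weaker inhibitor), a value of 501 nM, the lowest of the three numbers to hand, yet within the scatter of both neighbours. Compound 3, `Cc1cccc(-c2ccccc2OC(C)C2=NCCN2)c1`, gives 537 nM in this assay, and compound 2, `CC(Oc1ccccc1-c1cccnc1)C1=NCCN1`, gives 933 nM. Among the compounds with values here, the only step between two measured compounds is a 1.7-fold lower number from compound 2 to compound 3 (0.24 log units; within the scatter), which changes the distal aromatic ring as a whole and not a substituent on it.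

Compound 4, `CC(Oc1ccccc1-c1ccc(O)cc1)C1=NCCN1`, differs from compound 1 by hydroxy in place of nitro on an aromatic carbon. Within the data shown here, no measured step touches a substituent on that ring, so nothing here bears directly on this change; the whole series sits within a narrow band regardless of which aryl group stands there. The expectation is therefore a step of no more than the scatter in this assay, in either direction, the estimated step being a 1.3-fold higher number from compound 1 to compound 4 (0.11 log units; within the scatter). Compound 4 is expected to give about 650 nM in this assay, with a range from 200 nM to 2100 nM.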

Compound 4, inhibition constant: 813 nM
Compound 4: middle estimate off by 1.3-fold (0.10 log units), on the low side; measured number inside the range.
By their numbers in this assay, from the lowest: compounds 1, 3, 4 and 2 (each within the scatter of the next).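

In this assay, within the data shown here, the first substituent exchange at this place, para to a large group, gives a 1.6-fold higher number from compound 1 to compound 4 (0.21 log units; within the scatter) and so does not separate hydroxy from nitro, although the two differ in heavy atoms and hydrogen-bond donors. The exchanges of the whole aryl group read alike: a 1.5-fold higher number from compound 3 to compound 4 (0.18 log units; within the scatter) and a 1.1-fold lower number from compound 2 to compound 4 (0.06 log units; within the scatter) leave 4-hydroxyphenyl inseparable from 3-methylphenyl and pyridin-3-yl. No independent evidence bearing on these results is at hand.

Still open, going by these compounds, is whether an amine, a carboxylic acid or a longer alkoxy chain at this place would stay within the same narrow band. The compounds shown also do not tell whether any substituent on this ring can produce a step beyond the scatter.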